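A few compounds are considered here, and "the series" means these few. Any claim that something is new, unique, unknown or untested is made for them only; others in the source may bear on it.

Working notes on the diarylalkyl urea series.

Compound 1 `O=C(NCCCCC(c1ccc(F)cc1)c1ccc(F)cc1)Nc1cccc(C(F)(F)F)c1` and compound 2 `O=C(NCCCCC(c1ccc(F)cc1)c1ccc(F)cc1)Nc1cccc([N+](=O)[O-])c1` share one core; compound 3 `COc1ccc(C(CCCCNC(=O)Nc2ccc(Cl)c(C(F)(F)F)c2)c2ccc(OC)cc2)cc1` and compound 4 `COc1ccc(C(CCCCNC(=O)Nc2ccc(Cl)c([N+](=O)[O-])c2)c2ccc(OC)cc2)cc1` share another. The difference between the two cores is not broken down here.

In a functional assay on MDA-MB-231 cells (Homo sapiens) for cytotoxicity, read by MTT assay, with a stated time of 48 h (on this read-out lower numbers stand for stronger inhibition and higher numbers for weaker inhibition), compound 1 gives 3380 nM, and compound 2 gives 3790 nM. The change from compound 1 to compound 2 is nitro in place of trifluoromethyl on an aromatic carbon, and it reads a 1.1-fold higher number from compound 1 to compound 2 (0.05 log units; within the scatter). In this assay compound 3 gives 3300 nM, which stands within the scatter of both compound 1 and compound 2.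

Compound 4 has not been measured. For the measured compounds named here, its change from compound 3 is nitro in place of trifluoromethyl on an aromatic carbon, the same kind of change as the one from compound 1 to compound 2, though the place is not identical: in compound 4 the nitro sits ortho to a chloro group (1 heavy atom) as well as meta to a large group, whereas in compound 2 it sits only meta to a large group. With one measured instance of this change, the expectation for compound 4 rests on that instance alone. Because the step of a 1.1-fold higher number from compound 1 to compound 2 (0.05 log units; within the scatter) stayed within the scatter, the step from compound 3 to compound 4 is expected to be small too, estimated at a 1.1-fold higher number from compound 3 to compound 4 (0.05 log units; within the scatter). For compound 4 in this assay the estimate is 3700 nM, expected to fall between 2000 nM and 7000 nM.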

Compound 4, half-maximal inhibitory concentration: 3990 nM
Compound 4: the middle estimate sits 1.1-fold (0.03 log units) below what was measured; low and high end bracket the measured number.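

In this assay the change of trifluoromethyl to nitro reads a 1.2-fold higher number from compound 3 to compound 4 (0.08 log units; within the scatter), and the step on the core of compound 3 agrees with the step on the core of compound 1: the same change on two cores in this assay, a 1.1-fold higher number (0.05 log units; within the scatter) from compound 1 to compound 2 and a 1.2-fold higher number (0.08 log units; within the scatter) from compound 3 to compound 4, 1.1-fold (0.03 log units) apart, within the scatter of two such steps. Across these two cores the change therefore carries over as a step too small to read, and this holds although the nitro in compound 4 sits ortho to a chloro group while the nitro in compound 2 has no such group ortho to it. For the compounds shown here, this rests on two pairs and one cell assay, both steps lie within the scatter, and the comparison says nothing about other cores or other read-outs, nor does it isolate any part played by the chloro group, as no pair here differs in that group alone.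

The compounds shown leave open whether a nitrile, a carboxylic acid or an amine on the same aromatic carbon would give a step beyond the scatter, in place of the two groups compared here. They also leave open whether the change would stay this small on a core with a longer chain between the urea and the two aryl rings.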